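Anilide substituent swap on the bis-benzylidene piperidinone core

The compounds below may be only part of what the source reports. "The series", "measured", "known", "first", "only" and "open" are said of these compounds alone.

Three compounds of the series have numbers in a functional assay on L1210 cells (Mus musculus) for cytotoxicity; a lower number here means a stronger inhibitor, a higher number a weaker inhibitor. Compound 1 `O=C(/C=C/C(=O)N1C/C(=C\c2ccccc2)C(=O)/C(=C/c2ccccc2)C1)Nc1ccc([N+](=O)[O-])cc1` gives 40000 nM. Compound 2 `O=C(/C=C/C(=O)N1C/C(=C\c2ccc([N+](=O)[O-])cc2)C(=O)/C(=C/c2ccc([N+](=O)[O-])cc2)C1)Nc1ccc(Cl)cc1` gives 3600 nM. Compound 3 `Cc1ccc(NC(=O)/C=C/C(=O)N2C/C(=C\c3ccccc3)C(=O)/C(=C/c3ccccc3)C2)cc1` gives 5800 nM, the second highest of the three numbers; its nearest neighbour is compound 2, within the scatter, and its furthest is compound 1, beyond the scatter. Among the measured compounds shown here, the one single-point step so far runs a 6.9-fold lower number from compound 1 to compound 3 (0.84 log units; beyond the scatter).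

Compound 4 `O=C(/C=C/C(=O)N1C/C(=C\c2ccccc2)C(=O)/C(=C/c2ccccc2)C1)Nc1ccc(Cl)cc1` differs from compound 3 in one place: chloro in place of methyl on an aromatic carbon. For the measured compounds named here, no measured step covers exactly this exchange. The step of a 6.9-fold lower number from compound 1 to compound 3 (0.84 log units; beyond the scatter) shows that the group on this aromatic carbon can move the number by a modest amount, but it concerns nitro, not chloro. Compound 2 carries the chloro anilide yet differs elsewhere as well, so its value of 3600 nM and the value of compound 3 only show that the two numbers lie within the scatter of each other.

On that basis the step of a 1.5-fold lower number from compound 3 to compound 4 (0.16 log units; within the scatter) is expected to stay small, probably toward a slightly lower number. Compound 4 is estimated at 4000 nM, with a range from 1500 nM to 12000 nM.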

Compound 4, half-maximal inhibitory concentration: 7800 nM
Estimate against measurement, compound 4: 2.0-fold (0.29 log units) below; the range from low to high includes it.
By their numbers in this assay, from the lowest: compounds 2, 3 and 4 (each within the scatter of the next, the first and the last beyond it); then compound 1.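

In this assay the exchange of methyl for chloro on this aromatic carbon, para to a large group, gives a 1.3-fold higher number from compound 3 to compound 4 (0.13 log units; within the scatter), so on the shared core these two anilide substituents cannot be told apart. The nitro anilide now stands apart from two partners instead of one: beside a 6.9-fold lower number from compound 1 to compound 3 (0.84 log units; beyond the scatter) there is a 5.1-fold lower number from compound 1 to compound 4 (0.71 log units; beyond the scatter), and among the three compounds that differ only at this carbon, compound 1 alone separates from the others, while compound 3 and compound 4 stay together. Nothing measured here bears on the reason for this split.

As far as these compounds go, whether an amine, a methoxy group or a carboxylic acid on this carbon would fall with methyl and chloro or with nitro remains open, as does the result of moving any of these groups to another carbon of the anilide ring. Compound 2 also carries nitro groups on both benzylidene rings, and no single-place step isolates them, so their contribution on the shared core cannot be read from the compounds shown.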